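A few compounds are considered here, and "the series" means these few. Any claim that something is new, unique, unknown or untested is made for them only; others in the source may bear on it.

Working notes on the series. Within the data shown here, in a functional assay on HUVEC cells (Homo sapiens), read by scintillation counting and thymidine incorporation, with a stated time of 24 h (on this read-out higher numbers stand for weaker inhibition and lower numbers for stronger inhibition), compound 1 (`CCC(C)n1ncn(-c2ccc(N3CCN(c4ccc(OC[C@@H]5CO[C@@](CC)(c6ccc(Cl)cc6Cl)O5)cc4)CC3)cc2)c1=O`) gives 353 nM and compound 2 (`CCC(C)n1ncn(-c2ccc(N3CCN(c4ccc(OC[C@@H]5CO[C@@](Cn6ccnc6C)(c6ccc(Cl)cc6Cl)O5)cc4)CC3)cc2)c1=O`) gives 173 nM, the lower of the two numbers so far. Compound 3 (`CCC(C)n1ncn(-c2ccc(N3CCN(c4ccc(OC[C@@H]5CO[C@@](Cn6c(C)cnc6C)(c6ccc(Cl)cc6Cl)O5)cc4)CC3)cc2)c1=O`) extends compound 2 by one substituent: methyl in place of hydrogen on an aromatic carbon. This places methyl in place of hydrogen on an aromatic carbon, turning 2-methyl-1H-imidazol-1-yl into 2,5-dimethyl-1H-imidazol-1-yl. Among the measured compounds shown here, the only measured step that bears on this is a 2.0-fold lower number from compound 1 to compound 2 (0.31 log units; beyond the scatter), which brought in 2-methyl-1H-imidazol-1-yl in place of methyl on a saturated chain carbon. That step is modest, and it involves a far larger exchange than a single methyl. For the measured compounds named here, no measured step covers a substituent on this aromatic ring. Only a small shift is therefore expected in this assay, a 1.1-fold lower number from compound 2 to compound 3 (0.03 log units; within the scatter), with no step beyond the scatter. The estimate for compound 3 is 160 nM, with an expected range of 75 nM to 340 nM.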

Compound 3, half-maximal inhibitory concentration: 765 nM
The estimate for compound 3 lay 4.8-fold (0.68 log units) below the measured number; the measured number lies above the stated range.
By their numbers in this assay, from the lowest: compound 2; then compound 1; then compound 3.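

In this assay, among these compounds, this aromatic carbon of the five-membered ring, a place no earlier compound varied, does not tolerate a single added methyl without loss, with a 4.4-fold higher number from compound 2 to compound 3 (0.65 log units; beyond the scatter) beyond the scatter. The added methyl also reverses the ranking against the simple chain end of compound 1: 2-methyl-1H-imidazol-1-yl gave a lower number than that chain end, whereas 2,5-dimethyl-1H-imidazol-1-yl gives a 2.2-fold higher number from compound 1 to compound 3 (0.34 log units; beyond the scatter). Nothing in the data available accounts for this loss.

Whether the loss is specific to methyl remains open, since the compounds shown carry only hydrogen or methyl on this carbon, and a fluorine, a chlorine or a hydroxymethyl group there could give a different number. Also open, going by these compounds, is how an imidazol-1-yl group without the 2-methyl substituent would stand against compound 2.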